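This account rests on a few compounds, and the source may have more. Where it says the series, first, only, none or still open, it means among the compounds named here.

The measured compounds in an ADME assay on MT4 cells (Homo sapiens) for cytotoxicity, read by MTT assay, with a stated time of 4 days; on this read-out lower numbers stand for higher toxicity in this test and higher numbers for lower toxicity in this test:

Compound 1 `Cc1cc(C)cc(Cn2c(=O)cc(N=[N+]=[N-])n(Cc3ccncc3)c2=O)c1` gives 59000 nM.
Compound 2 `Cc1cc(C)cc(Cn2c(=O)cc(N3CCNCC3)n(Cc3ccccc3)c2=O)c1` gives 16000 nM.
Compound 3 `Cc1cc(C)cc(Cn2c(=O)cc(N)n(Cc3ccccn3)c2=O)c1` reaches only the assay limit, > 100000 nM.

Among the two numbers actually reported, compound 2 stands lowest, and the nearest number, that of compound 1, lies beyond the usual scatter above it. The result for compound 3 is a limit and not a number, and the same limit is described by the limit of > 100000 nM in this assay, at which 1 of the 3 values shown sits. Among the measured compounds shown here, no step between two measured compounds differing in one place is available here, so the series gives no calibrated change to lean on.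

Compound 4 `CC(=O)Nc1cc(=O)n(Cc2cc(C)cc(C)c2)c(=O)n1Cc1ccccc1` is not yet measured. It differs from compound 2 as follows: acetamido in place of piperazin-1-yl on an aromatic carbon. Since compound 3, which carries a small neutral group at the same position, gives only a limit, compound 4 is expected to move upward in this assay, away from compound 2, by a step of a 3.8-fold higher number from compound 2 to compound 4 (0.57 log units; beyond the scatter), likely beyond the scatter. Compound 4 is therefore estimated at 60000 nM, with a range from 20000 nM to 150000 nM.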

Compound 4, half-maximal cytotoxic concentration: > 100000 nM
Compound 4 gave a limit, no number (the forecaster's own chance of this, stated with the estimate: 35%); at least 1.6-fold (0.22 log units) between middle value and limit.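

Among the compounds shown here, replacing piperazin-1-yl with acetamido on this aromatic carbon, with the benzyl and 3,5-dimethylbenzyl groups unchanged, gives in this assay the first comparison that differs in one place: an at least 6.2-fold higher number from compound 2 to compound 4 (0.79 log units; beyond the scatter). The group at this position alone can therefore shift the read-out beyond the scatter, towards lower toxicity in this test. Compound 4 gives > 100000 nM, which is a limit of the assay and not a number, and this limit now recurs in the series: the limit of > 100000 nM in this assay, at which 2 of the 4 values shown sit.

As far as these compounds go, the full size of the step remains open, since only its lower bound can be read. Also open, from the compounds shown here alone, is whether a morpholin-4-yl group or an open-chain amine such as dimethylamino at this carbon would stay close to compound 2 or reach the limit.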